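Piperazine swap on the core of compound 1

A few compounds are considered here, and "the series" means these few. Any claim that something is new, unique, unknown or untested is made for them only; others in the source may bear on it.

Compound 1 `C[C@@H]1CN(c2cccc3c2C[C@H](CN(C)[C@H]2CCCc4cccnc42)NC3)C[C@H](C)N1` gives 100% in an ADME assay on microsomes from liver (Homo sapiens) for metabolic stability, read by LC-MS, with a stated time of 10 min (a higher number here means that more of the compound is left, a lower number that less of the compound is left), the highest of three numbers. Compound 3 `CN(C[C@H]1Cc2c(cccc2N2CCN(c3cccc(C(F)(F)F)c3)CC2)CN1)[C@H]1CCCc2cccnc21` gives 90.3% in this assay, within the scatter of compound 1, while compound 2 `CN(C[C@H]1Cc2c(cccc2N2CCN(C3CC3)CC2)CN1)[C@H]1CCCc2cccnc21` gives 15.5%. Compound 4 `CCN1CCN(c2cccc3c2C[C@H](CN(C)[C@H]2CCCc4cccnc42)NC3)CC1` differs from compound 1 in one place: 4-ethylpiperazin-1-yl in place of 3,5-dimethylpiperazin-1-yl on an aromatic carbon. Among the measured compounds shown here, two measured steps bear on it. Moving to an N-substituted piperazine produced a number 84.5 percentage points lower from compound 1 to compound 2 (beyond the scatter), and changing that substituent produced a number 74.8 percentage points higher from compound 2 to compound 3 (beyond the scatter), so the group on the ring nitrogen mattered greatly. Compound 4 carries an ethyl group there, closer to compound 2 than to compound 3, so a drop is expected, a number 65 percentage points lower from compound 1 to compound 4 (beyond the scatter). Compound 4 is therefore estimated at 35%, between 10% and 75%.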

Compound 4, percent of the compound remaining: 0%
Estimate against measurement, compound 4: 35 percentage points above; the whole stated range lies above it.
By their numbers in this assay, from the lowest: compound 4; then compound 2; then compounds 3 and 1 (each within the scatter of the next).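

In this assay, the change at the amine nitrogen in a ring gave a number 90.3 percentage points lower from compound 3 to compound 4 (beyond the scatter), while ethyl in place of cyclopropyl gave only a number 15.5 percentage points lower from compound 2 to compound 4 (beyond the scatter), so ethyl and cyclopropyl both stand far from 3-(trifluoromethyl)phenyl there. With a number 100 percentage points lower from compound 1 to compound 4 (beyond the scatter), two piperazine groups of equal heavy-atom count end at opposite extremes, so that count alone does not set the number. No evidence here accounts for these steps.

The compounds shown leave open how a propyl chain or an unsubstituted phenyl on that nitrogen would behave.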